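The source may hold more compounds than are shown below. What is called first, only, known or untested is meant among the compounds shown, and "the series" means these compounds.

Measured compounds in a functional assay on SGC-7901 cells (Homo sapiens) for inhibition, read by MTT assay, with a stated time of 24 h; on this read-out higher numbers stand for weaker inhibition and lower numbers for stronger inhibition:

Compound 1 `CC1(C)[C@H]2CC[C@]1(C)N(Cc1cn(-c3ccccc3Br)nn1)C(=O)C2` gives 500 nM.
Compound 2 `CC1(C)[C@H]2CC[C@]1(C)N(Cc1cn(-c3ccc(C#N)cc3)nn1)C(=O)C2` gives 500 nM.
Compound 3 `CC1(C)[C@H]2CC[C@]1(C)N(Cc1cn(-c3ccccc3C#N)nn1)C(=O)C2` gives 260 nM.

Among the compounds with values here, compound 2 stands level with compound 1 at the digits printed, and its only other neighbour is compound 3, reached by a 1.9-fold lower number from compound 2 to compound 3 (0.28 log units; within the scatter). Compound 4 `CC1(C)[C@H]2CC[C@]1(C)N(Cc1cn(-c3cccc(C#N)c3)nn1)C(=O)C2` is the unmeasured member; it differs from compound 2 by 3-cyanophenyl in place of 4-cyanophenyl on an aromatic nitrogen. Within the data shown here, two measured steps bear on this move of the cyano group around the ring: a 1.9-fold lower number from compound 2 to compound 3 (0.28 log units; within the scatter) and, for a different substituent, a 1.9-fold lower number from compound 1 to compound 3 (0.28 log units; within the scatter); both lie within the scatter, and so does no change at the digits printed from compound 1 to compound 2 (within the scatter). Nothing shown therefore points to a step beyond the scatter in this assay, in either direction. Compound 4 is accordingly expected at 400 nM, with a range of 200 nM to 900 nM, meaning an estimated 1.3-fold lower number from compound 2 to compound 4 (0.10 log units; within the scatter).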

Compound 4, half-maximal inhibitory concentration: 250 nM
Estimate against measurement, compound 4: 1.6-fold (0.20 log units) above, and the stated range covers the measured number.
By their numbers in this assay, from the lowest: compounds 4, 3, 1 and 2 (each within the scatter of the next).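

In this assay, 3-cyanophenyl joins 2-cyanophenyl and 4-cyanophenyl, and the move of the nitrile stays within the scatter on both comparisons (a 2.0-fold lower number from compound 2 to compound 4 (0.30 log units; within the scatter); a 1.0-fold lower number from compound 3 to compound 4 (0.02 log units; within the scatter)). Replacing 2-bromophenyl gives the same reading (a 2.0-fold lower number from compound 1 to compound 4 (0.30 log units; within the scatter)), so this position shows no step beyond the scatter among the four aryl groups. Nothing measured here accounts for these numbers.

On these data alone, whether an amine or a carboxylic acid in place of the nitrile gives a step beyond the scatter remains open. As far as these compounds go, the effect of a longer chain between the shared core and the aromatic ring also remains open.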